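The compounds below may be only part of what the source reports. "The series", "measured", "known", "first", "only" and "open" are said of these compounds alone.

Compound 1 `N#CC1(c2cc(CCO)cc(-c3ccnc4[nH]nc(C(F)(F)F)c34)c2)CC1` gives 17%
Compound 2 `N#CC1(c2cc(CC(O)C3CC3)cc(-c3ccnc4[nH]nc(C(F)(F)F)c34)c2)CC1` gives 0%
Compound 3 `N#CC1(c2cc(CC(O)C(F)(F)F)cc(-c3ccnc4[nH]nc(C(F)(F)F)c34)c2)CC1` gives 71%

In an ADME assay on S9 fraction from liver (Rattus norvegicus) for metabolic stability, read by LC-MS, using NADPH, with a stated time of 60 min, tested at 10 uM (on this read-out lower numbers stand for a less stable compound and higher numbers for a more stable compound), compound 3 stands highest of the three, with 71% as its number. Trifluoromethyl on the saturated chain carbon bound to an oxygen goes with a number 54 percentage points higher from compound 1 to compound 3 (beyond the scatter), a large step. Cyclopropyl at that place goes with a number 17 percentage points lower from compound 1 to compound 2 (beyond the scatter), a modest one. The gap between those two substituents is a number 71 percentage points higher from compound 2 to compound 3 (beyond the scatter), also large.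

Compound 4 `N#CC1(c2cc(CC(=O)O)cc(-c3ccnc4[nH]nc(C(F)(F)F)c34)c2)CC1` has not yet been measured. It differs from compound 3 by carboxy in place of 2,2,2-trifluoro-1-hydroxyethyl on a saturated chain carbon bound to an aromatic carbon.

Among the compounds with values here, no measured step makes this exchange, and the three steps bear on it only indirectly. Trifluoromethyl leaves, and its arrival came with a number 54 percentage points higher from compound 1 to compound 3 (beyond the scatter), which warns of a possible fall. Within the data shown here, the oxygen-bearing carbon leaves with it, however, and no carboxy compound has been measured for comparison. A small step with no firm direction seems the fairest expectation, with a wide margin on the low side. The expected step is a number 4 percentage points higher from compound 3 to compound 4 (within the scatter). For compound 4 the estimated value is 75%, with an expected range from 40% to 98%.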

Compound 4, percent of the compound remaining: 95%
Beside the measured number, compound 4's estimate is 20 percentage points below it, within the range that was stated.
By their numbers in this assay, from the lowest: compound 2; then compound 1; then compound 3; then compound 4.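

In this assay, carboxy on a saturated chain carbon bound to an aromatic carbon stands above all three hydroxy-bearing groups shown at this place. In place of 2,2,2-trifluoro-1-hydroxyethyl it gives a number 24 percentage points higher from compound 3 to compound 4 (beyond the scatter), in place of cyclopropyl(hydroxy)methyl it gives a number 95 percentage points higher from compound 2 to compound 4 (beyond the scatter), and in place of hydroxymethyl it gives a number 78 percentage points higher from compound 1 to compound 4 (beyond the scatter). The earlier compounds left open whether a high number here depended on trifluoromethyl, and compound 4 shows that it does not, since a group with no fluorine and three heavy atoms against six stands higher still, although nothing available explains this rise.

On these data alone, it remains open whether the carboxy group itself is what matters, or whether a primary amide or a methyl ester at the same place would give a similar number. Within the data shown here, a longer chain ending in a carboxylic acid, or a tetrazole in place of the carboxy group, would show how far this result extends beyond the single group seen here.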